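Fluoro to hydrogen in the series: expectation for compound 3

This account rests on a few compounds, and the source may have more. Where it says the series, first, only, none or still open, it means among the compounds named here.

Measured in an ADME assay on L1210/0 cells (Mus musculus) for cytotoxicity, with a stated time of 48 h; on this read-out lower numbers stand for stronger inhibition and higher numbers for weaker inhibition:
- compound 1 `O=C1OC(C(O)Cn2cc(C(F)(F)F)c(=O)[nH]c2=O)C(OCc2ccccc2)=C1OCc1ccccc1`: 50200 nM
- compound 2 `O=C1OC(C(O)Cn2cc(F)c(=O)[nH]c2=O)C(OCc2ccccc2)=C1OCc1ccccc1`: 140000 nM

Among the measured compounds shown here, compound 2, at 140000 nM, holds the higher of the two numbers so far. For the measured compounds named here, compound 1, at 50200 nM, is its only neighbour.

Compound 3 `O=C1OC(C(O)Cn2ccc(=O)[nH]c2=O)C(OCc2ccccc2)=C1OCc1ccccc1` has not yet been measured. Its difference from compound 2 is hydrogen in place of fluoro on an aromatic carbon. In words, this is hydrogen in place of fluoro on an aromatic carbon.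

Going by the values given here, only one measured step bears on this change: a 2.8-fold higher number from compound 1 to compound 2 (0.45 log units; beyond the scatter). That step, fluoro in place of trifluoromethyl on an aromatic carbon, is modest but beyond the scatter. It also changes the group on an aromatic carbon, and it went towards a higher number. Among the compounds with values here, one step establishes no pattern, and no measured pair shows hydrogen at this place, so the direction is a tentative extrapolation. A small further move towards a higher number in this assay is expected, and it may not clear the scatter. The expected step is a 1.4-fold higher number from compound 2 to compound 3 (0.15 log units; within the scatter). For compound 3 the estimated value is 200000 nM, with an expected range of 100000 nM to 400000 nM.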

Compound 3, half-maximal inhibitory concentration: 157000 nM
Compound 3: the middle estimate sits 1.3-fold (0.11 log units) above what was measured; measured number inside the range.
By their numbers in this assay, from the lowest: compound 1; then compounds 2 and 3 (each within the scatter of the next).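

In this assay, hydrogen in place of fluoro on this aromatic carbon gives a 1.1-fold higher number from compound 2 to compound 3 (0.05 log units; within the scatter) and so the read-out does not separate these two groups at this place. Hydrogen in place of trifluoromethyl gives a 3.1-fold higher number from compound 1 to compound 3 (0.50 log units; beyond the scatter) and this, read with the first point, sets compound 1 apart from compound 2 and compound 3, so the three compounds form one distinct group and a pair rather than a graded run. Nothing measured here explains why trifluoromethyl stands apart from fluoro and hydrogen.

The compounds shown leave open whether the separation is specific to trifluoromethyl or would extend to other groups on this carbon, such as a methyl, an ethyl chain, a nitrile, an amine or a carboxylic acid. They also leave open whether the same ordering of these three groups would hold with a change elsewhere on the shared core, since all three compounds carry the same core and differ only at this one place.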